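Extending the Ether Chain Toward Compound 4

This account rests on a few compounds, and the source may have more. Where it says the series, first, only, none or still open, it means among the compounds named here.

Measured so far in an assay on cells with melanin-concentrating hormone receptor 1 (Homo sapiens) as the target, read by radioligand binding; on this read-out lower numbers stand for stronger inhibition and higher numbers for weaker inhibition:
- compound 1, `CC1CC1COc1cccc2ccc(N)nc12`, gives 1640 nM
- compound 2, `CCCCOc1cccc2ccc(N)nc12`, gives 789 nM
- compound 3, `CSCCOc1cccc2ccc(N)nc12`, gives > 2000 nM

For compound 3 the result is not a number but a limit of this assay, namely (the limit of > 2000 nM in this assay, at which 1 of the 3 values shown sits). Compound 3 therefore has no exact position among the three, only a floor on how weak it is. Of the measured steps, a 2.1-fold lower number from compound 1 to compound 2 (0.32 log units; beyond the scatter) shows a modest gain, while an at least 2.5-fold higher number from compound 2 to compound 3 (0.40 log units; beyond the scatter) shows a loss that is at least modest.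

Compound 4, `COCCOCCOc1cccc2ccc(N)nc12`, differs from compound 3 as follows: 2-methoxyethoxy in place of methylsulfanyl on a saturated chain carbon, two bonds along the chain from an oxygen on an aromatic ring. Among the measured compounds shown here, only the step from compound 2 to compound 3 touches the same place, and it shows that a change there can cost potency. For the measured compounds named here, no measured step brings in an ether chain of this kind, so the direction of the new step cannot be read from the data, and the starting point is itself only a limit. For compound 4 the expected step is a step that the limit leaves unreadable from compound 3 to compound 4. The value of compound 4 is estimated at 3000 nM, with a range from 800 nM to 12000 nM, and a real chance that only a limit is reported again.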

Compound 4, half-maximal inhibitory concentration: > 2000 nM
Compound 4 ended at the assay's limit (the forecaster's own chance of this, stated with the estimate: 60%); the middle value lies beyond the limit too.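

In this assay compound 4 gives > 2000 nM, which is a limit of the assay and not a number; compound 3 sits at the same limit, so the step between them cannot be read and the two cannot be ranked: the limit of > 2000 nM in this assay, at which 2 of the 4 values shown sit. What is new comes from the comparison with ethyl at this place, on a saturated chain carbon, two bonds along the chain from an oxygen on an aromatic ring: 2-methoxyethoxy gives an at least 2.5-fold higher number from compound 2 to compound 4 (0.40 log units; beyond the scatter), so methylsulfanyl is no longer the only group shown to lose potency against ethyl there. The comparison with the 2-methylcyclopropyl compound tells much less, giving only an at least 1.2-fold higher number from compound 1 to compound 4 (0.08 log units; that floor lies within the scatter), which sets no order between the two.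

The compounds shown leave open how far past the limit compound 3 and compound 4 really lie, and which of them is the weaker. They also leave open whether a plain longer chain such as pentyl, or a chain ending in an amine, would match or improve on compound 2 at this place.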